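Replacing Aminophenyl With Methylphenyl on the Amide Nitrogen

The source may hold more compounds than are shown below. What is called first, only, known or untested is meant among the compounds shown, and "the series" means these compounds.

The shared core carries an amide whose nitrogen substituent is varied. In a functional assay on the whole organism for inhibition, with Rattus norvegicus as the target, read by paw edema, at a dose of 100 mg/kg by the oral route (a higher number here means more inhibition at the dose given (going by the name of the read-out), a lower number less inhibition), compound 1 `O=C(NCc1ccccc1)c1c(O)c2cccnc2n(-c2ccccc2)c1=O` gives 1.6%, and compound 2 `Nc1ccc(NC(=O)c2c(O)c3cccnc3n(-c3ccccc3)c2=O)cc1` gives -5.5%. The single measured step, a number 7.1 percentage points lower from compound 1 to compound 2 (within the scatter), is within the scatter, so compound 2 and compound 1 lie within the scatter of each other and neither stands apart on the numbers shown.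

Compound 3 `Cc1ccccc1NC(=O)c1c(O)c2cccnc2n(-c2ccccc2)c1=O` differs from compound 2 by 2-methylphenyl in place of 4-aminophenyl on an amide-type nitrogen. The only step that bears on this change is the swap of benzyl for 4-aminophenyl on the same amide-type nitrogen, and it moved the read-out by an amount within the scatter; nothing shown suggests that 2-methylphenyl would move it further.

Compound 3 is therefore expected to show no step beyond the scatter, a number 5.5 percentage points higher from compound 2 to compound 3 (within the scatter), and its inhibition is estimated at 0%, between -15% and 15%.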

Compound 3, a percentage reported as inhibition, in the whole organism at one dose (the size of the read-out at that dose, not a potency): 11.7%
Estimate against measurement, compound 3: 11.7 percentage points below, within the range that was stated.
By their numbers in this assay, from the lowest: compounds 2 and 1 (each within the scatter of the next); then compound 3.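

At this amide-type nitrogen, the substituent can move the read-out in this assay beyond the scatter, which the earlier swap of benzyl for 4-aminophenyl did not show. 2-methylphenyl in place of 4-aminophenyl gives a number 17.2 percentage points higher from compound 2 to compound 3 (beyond the scatter), and 2-methylphenyl in place of benzyl gives a number 10.1 percentage points higher from compound 1 to compound 3 (beyond the scatter), so compound 3 stands apart from both earlier compounds, though both steps are modest. No evidence is available to explain this difference.

The compounds shown leave open whether the methyl group itself matters, as an unsubstituted phenyl would help to show, and whether other groups at this nitrogen, such as a chlorophenyl, a methoxyphenyl or a longer alkyl chain, would go further. They also leave open how compound 3 would behave at any other dose.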